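Aryl ether variation in a cyclopropane hydrazide series

The source may hold more compounds than are shown below. What is called first, only, known or untested is meant among the compounds shown, and "the series" means these compounds.

Measured so far:
compound 1 `O=C(NNC(=O)C1CC1c1ccc(OC(F)(F)F)cc1)c1ccncc1` — > 100000 nM
compound 2 `CCOc1ccc(C2CC2C(=O)NNc2nncc3ccccc23)cc1` — 94000 nM
compound 3 `CC(C)=CCC/C(C)=C/COc1ccc(C2CC2C(=O)NNc2nncc3ccccc23)cc1` — 24000 nM

In a functional assay on PC-3 cells (Homo sapiens) for inhibition, read by MTT assay, with a stated time of 72 h (on this read-out lower numbers stand for stronger inhibition and higher numbers for weaker inhibition), compound 1 reports only a limit, > 100000 nM; this is the limit of the assay, not a number, and the limit of > 100000 nM in this assay, at which 1 of the 3 values shown sits, shows how many of the values here sit at it. Compound 2 gives 94000 nM in this assay, and compound 3 gives 24000 nM.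

Compound 4 `O=C(NNC(=O)C1CC1c1ccc(OCC(F)(F)F)cc1)c1ccncc1` is the unmeasured compound. Its difference from compound 1 is 2,2,2-trifluoroethyl in place of trifluoromethyl on an oxygen on an aromatic ring.

Within the data shown here, the only measured step in this assay is a 3.9-fold lower number from compound 2 to compound 3 (0.59 log units; beyond the scatter), which also lengthens the group on the aromatic ether oxygen, though with a far larger chain and on a different shared core. Among the measured compounds shown here, that step is modest, and it is the sole guide here. For compound 4 a step of similar direction but smaller size is therefore expected, a number no higher from compound 1 to compound 4 (the limit leaves the size open), with the caveat that compound 1 starts at the limit, so the result for compound 4 may again be reported only as a limit.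

The estimate for compound 4 in this assay is 100000 nM, expected to fall between 40000 nM and 300000 nM.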

Compound 4, half-maximal inhibitory concentration: 44000 nM
The estimate for compound 4 lay 2.3-fold (0.36 log units) above the measured number, and the stated range covers the measured number.
By their numbers in this assay, from the lowest: compounds 3 and 4 (each within the scatter of the next); then compound 2. At a limit, above all of these: compound 1.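

Replacing trifluoromethyl with 2,2,2-trifluoroethyl on the oxygen on the aromatic ring gives an at least 2.2-fold lower number from compound 1 to compound 4 (0.35 log units; beyond the scatter) in this assay, which shows that the core of this pair responds to a small change at this oxygen. The earlier evidence for a response at this oxygen was a 3.9-fold lower number from compound 2 to compound 3 (0.59 log units; beyond the scatter), a change involving a far larger chain on a different shared core, so it did not establish that so small a change could register on this core. Compound 1 stands at a limit of the assay, > 100000 nM, and the full size of the step stays open because of that limit: the limit of > 100000 nM in this assay, at which 1 of the 4 values shown sits.

The compounds shown leave open whether a plain ethyl group or a longer chain such as 3,3,3-trifluoropropyl on this oxygen would move the number further on the core of compound 4, and whether an amine or a carboxylic acid at the end of such a chain would be tolerated. Among these compounds, they also leave open whether the fluorine atoms matter to the step, since no matched pair here separates them from chain length.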